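A few compounds are considered here, and "the series" means these few. Any claim that something is new, unique, unknown or untested is made for them only; others in the source may bear on it.

Compounds and values:
- compound 1, `Cc1ccccc1-n1nncc1CN1C(=O)C2(C(C#N)=C(N)Oc3c2c2nc4ccccc4nc2c2ccccc32)c2ccccc21`: > 50000 nM
- compound 2, `CCOc1ccccc1-n1nncc1CN1C(=O)C2(C(C#N)=C(N)Oc3c2c2nc4ccccc4nc2c2ccccc32)c2ccccc21`: > 50000 nM
- compound 3, `COc1ccccc1-n1nncc1CN1C(=O)C2(C(C#N)=C(N)Oc3c(N)cc4nc5ccccc5nc4c32)c2ccccc21`: 28900 nM

In a functional assay on MCF7 cells (Homo sapiens) for antiproliferative activity, read by MTT assay, with a stated time of 48 h (a lower number here means a stronger inhibitor, a higher number a weaker inhibitor), compound 1 gives > 50000 nM, which is a limit of the assay and not a number. In this assay compound 2 likewise gives > 50000 nM, again a limit. Within the data shown here, compound 3 is therefore the only member of the set with a number in this assay, 28900 nM, and it stands alone there. No ordering of compound 3 against compound 1 or compound 2 follows. Among the measured compounds shown here, the single step between measured compounds, a step that the two limits leave unreadable from compound 1 to compound 2, is unreadable because the limit of > 50000 nM in this assay, at which 2 of the 3 values shown sit, covers both ends of it, so nothing is known about how a change on the aryl group attached to the triazole moves the read-out.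

Compound 4, `N#CC1=C(N)Oc2c(N)cc3nc4ccccc4nc3c2C12C(=O)N(Cc1cnnn1-c1ccc(F)c(Cl)c1)c1ccccc12`, is to be measured in this assay. It differs from compound 3 by 3-chloro-4-fluorophenyl in place of 2-methoxyphenyl on an aromatic nitrogen. For the measured compounds named here, no measured step bears on this change; the only readable anchor is compound 3 itself. With the core of compound 3 retained and the aryl group exchanged, the expectation is that compound 4 stays in the weak range, with an expected step of a 1.0-fold lower number from compound 3 to compound 4 (0.01 log units; within the scatter) of no clear direction beyond the scatter. Compound 4 is thus estimated at 28000 nM, within 9000 nM to 50000 nM.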

Compound 4, half-maximal inhibitory concentration: 17800 nM
For compound 4 the middle estimate is 1.6-fold (0.20 log units) above the measured one; measured number inside the range.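

In this assay, among these compounds, the exchange of 2-methoxyphenyl for 3-chloro-4-fluorophenyl gives a 1.6-fold lower number from compound 3 to compound 4 (0.21 log units; within the scatter) as the first readable step for a change of aryl group on the aromatic nitrogen of the five-membered ring. With the rest of compound 3 kept, this position accepts a fluorine and chlorine pattern in place of the methoxy group with no shift that can be told from the scatter, and compound 4 still gives a number in this read-out. Nothing measured in this set accounts for the size of this step.

The aryl change from compound 1 to compound 2 cannot be read, so the set holds only one readable step at this position, and its two ends share the same core: the limit of > 50000 nM in this assay, at which 2 of the 4 values shown sit.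

Going by these compounds, whether an amine or a carboxylic acid on this aryl ring, or a longer chain in place of the methoxy group, would move the number beyond the scatter remains open.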